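Removing a methyl from a methoxy: expectation for compound 3

The compounds below may be only part of what the source reports. "The series", "measured", "known", "first", "only" and "open" are said of these compounds alone.

Measured so far:
compound 1 `Cc1cc(O)cc(-c2nn(CC#N)cc2-c2ccnc(-c3ccc(Oc4ccccc4)cc3)c2)c1` 99%
compound 2 `COc1cc(C)cc(-c2nn(CC#N)cc2-c2ccnc(-c3ccc(N(C)C)cc3)c2)c1` 102%

Both numbers come from a functional assay on MOLT-4 cells (Homo sapiens) for cytotoxicity, read by sulforhodamine B assay, with a stated time of 48 h, tested at 0.001 uM; on this read-out higher numbers stand for a weaker effect at the one concentration tested and lower numbers for a stronger effect. In this assay compound 1 gives 99% and compound 2 gives 102%; the two values lie within the usual scatter of each other, so neither compound can be told apart from the other, and both show essentially no effect at the single concentration tested. Compound 2 therefore stands alongside compound 1, with nothing to separate them.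

The next compound, compound 3 `Cc1cc(O)cc(-c2nn(CC#N)cc2-c2ccnc(-c3ccc(N(C)C)cc3)c2)c1`, differs from compound 2 in one place: hydrogen in place of methyl on an oxygen on an aromatic ring. Compound 1 already carries the hydroxy form of that ring, and in this assay compound 1 gives 99%, a number indistinguishable from that of compound 2. Going by the values given here, no step between measured compounds is available here, so the expectation rests on those two values alone. The step of a number 2 percentage points lower from compound 2 to compound 3 (within the scatter) is expected to be none beyond the scatter. Compound 3 is accordingly estimated at 100%, with a range from 90% to 108%.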

Compound 3, a percentage reported as activity, at one concentration (the size of the read-out at that concentration, not a potency): 100%
Beside the measured number, compound 3's estimate shows no gap at the digits printed; low and high end bracket the measured number.
By their numbers in this assay, from the lowest: compounds 1, 3 and 2 (each within the scatter of the next).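

In this assay, going from methoxy to hydroxy on the 3-methoxy-5-methylphenyl ring is a step of a number 2 percentage points lower from compound 2 to compound 3 (within the scatter), so with dimethylamino held constant, hydrogen in place of methyl on this oxygen cannot be told apart from no change at all. Going by these compounds alone, this compound also gives the first comparison that isolates a single change at the other end of the molecule, as the earlier pair differed in two places: dimethylamino in place of phenoxy on an aromatic carbon is a step of a number 1 percentage points higher from compound 1 to compound 3 (within the scatter), which again stays within the scatter. Nothing measured here offers an explanation for either result.

All three compounds were read at a single concentration, where none shows a clear effect, so these steps leave open whether either change would matter at a concentration where the compounds do act on the cells. Also open, on these data alone, is whether an ethyl or a longer chain on that oxygen, or a carboxylic acid or a primary amine in place of dimethylamino, would give a number beyond the scatter.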